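Benzylamine sulfonamides: compound 3 to a dimethoxyphenyl analogue

The source may hold more compounds than are shown below. What is called first, only, known or untested is meant among the compounds shown, and "the series" means these compounds.

Measured compounds and their values:
Compound 1 `O=S(=O)(NCCCNCc1cccc2ccccc12)c1cc(C(F)(F)F)cc(C(F)(F)F)c1`: in a functional assay on A2780 cells (Homo sapiens) for inhibition, read by MTT assay, with a stated time of 72 h (a lower number here means a stronger inhibitor of growth, a higher number a weaker inhibitor of growth), compound 1 gives 3100 nM.
Compound 2 `O=S(=O)(NCCCCNCc1ccc(Br)cc1)c1cc(C(F)(F)F)cc(C(F)(F)F)c1`: in this assay compound 2 gives 2100 nM.
Compound 3 `O=S(=O)(NCCCNCc1ccc(Cl)cc1)c1cc(C(F)(F)F)cc(C(F)(F)F)c1`: in this assay compound 3 gives 1800 nM.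

Compound 3 sits at the low end of the three numbers, but it is not set apart: the step of a 1.7-fold lower number from compound 1 to compound 3 (0.24 log units; within the scatter) and the step of a 1.2-fold lower number from compound 2 to compound 3 (0.07 log units; within the scatter) are both within the scatter, so the three compounds read as one band.

The next compound is compound 4 `COc1ccc(CNCCCNS(=O)(=O)c2cc(C(F)(F)F)cc(C(F)(F)F)c2)cc1OC`. It differs from compound 3 in one place: 3,4-dimethoxyphenyl in place of 4-chlorophenyl on a saturated chain carbon bound to an amine nitrogen.

Among the measured compounds shown here, only one measured step changes the same place, the aryl group on the saturated chain carbon bound to the amine nitrogen: a 1.7-fold lower number from compound 1 to compound 3 (0.24 log units; within the scatter), within the scatter. The step of a 1.2-fold lower number from compound 2 to compound 3 (0.07 log units; within the scatter) touches the chain as well as the aryl and is also within the scatter. For the measured compounds named here, no measured compound carries a methoxy group, so there is no direct precedent for the entering 3,4-dimethoxyphenyl. On this footing the expected step of a 1.4-fold higher number from compound 3 to compound 4 (0.14 log units; within the scatter) is small, with no direction claimed beyond the scatter.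

Compound 4 is therefore estimated at 2500 nM in this assay, with a range from 1000 nM to 6500 nM.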

Compound 4, concentration for 50% growth inhibition: 3800 nM
For compound 4 the middle estimate is 1.5-fold (0.18 log units) below the measured one; low and high end bracket the measured number.
By their numbers in this assay, from the lowest: compounds 3, 2, 1 and 4 (each within the scatter of the next, the first and the last beyond it).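

In this assay the aryl group on a saturated chain carbon bound to an amine nitrogen gives its first step beyond the scatter, with a 2.1-fold higher number from compound 3 to compound 4 (0.32 log units; beyond the scatter) as a modest change when 3,4-dimethoxyphenyl replaces 4-chlorophenyl. Replacing naphthalen-1-yl with the same 3,4-dimethoxyphenyl gives a 1.2-fold higher number from compound 1 to compound 4 (0.09 log units; within the scatter) and stays within the scatter, so the change at this position registers against the 4-chlorophenyl compound only, and even there the separation is small. No measurement on these compounds offers an explanation for the step from 4-chlorophenyl to 3,4-dimethoxyphenyl.

The compounds shown do not separate the effect of gaining the dimethoxy pattern from that of losing the chlorine, and 4-methoxyphenyl and 3-methoxyphenyl analogues on the same chain would be needed to tell these apart and to show whether a single methoxy group is enough. From the compounds shown here alone, it also remains open whether a 3,4-dichlorophenyl group would hold the number of compound 3 or move it further from that of compound 4.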